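Amine swap from compound 2 to compound 4

A few compounds are considered here, and "the series" means these few. Any claim that something is new, unique, unknown or untested is made for them only; others in the source may bear on it.

In a functional assay on MV4-11 cells (Homo sapiens) for inhibition, read by luminescence, with a stated time of 72 h (a higher number here means a weaker inhibitor, a lower number a stronger inhibitor), the series reads as follows.
- compound 1 `CCN1C(=O)COc2c(CN3CCN(C(C)C)CC3)cc(Nc3ncc(F)c(-c4ccc(F)cc4OC)n3)cc21` gives 149 nM
- compound 2 `CCN1C(=O)COc2c(CN3CCCCC3)cc(Nc3ncc(F)c(-c4ccc(F)cc4OC)n3)cc21` gives 50 nM
- compound 3 `CCN(CC)Cc1cc(Nc2ncc(F)c(-c3ccc(F)cc3OC)n2)cc2c1OCC(=O)N2CC` gives 26 nM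

Compound 2 belongs to the lower pair of values, as a 1.9-fold lower number from compound 2 to compound 3 (0.28 log units; within the scatter) shows, and compound 1 stands clear of that pair. Compound 4 `CCN1C(=O)COc2c(CN3CCC(N(C)C)C3)cc(Nc3ncc(F)c(-c4ccc(F)cc4OC)n3)cc21` differs from compound 2 by 3-(dimethylamino)pyrrolidin-1-yl in place of piperidin-1-yl on a saturated chain carbon bound to an aromatic carbon on the same carbon. The closest comparison is 4-isopropylpiperazin-1-yl, which also bears a further amine, and the steps away from it are a 3.0-fold lower number from compound 1 to compound 2 (0.47 log units; beyond the scatter) and a 5.7-fold lower number from compound 1 to compound 3 (0.76 log units; beyond the scatter) in size. This single precedent suggests a rise in this assay that is smaller than those steps and may stay within the scatter. The expected step is a 1.8-fold higher number from compound 2 to compound 4 (0.26 log units; within the scatter) on this reasoning. For compound 4 the estimate is 90 nM with an expected range of 30 nM to 250 nM here.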

Compound 4, half-maximal inhibitory concentration: 124 nM
Compound 4: middle estimate off by 1.4-fold (0.14 log units), on the low side; the range from low to high includes it.
By their numbers in this assay, from the lowest: compounds 3 and 2 (each within the scatter of the next); then compounds 4 and 1 (each within the scatter of the next).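

In this assay, 3-(dimethylamino)pyrrolidin-1-yl in place of piperidin-1-yl on the saturated chain carbon gives a 2.5-fold higher number from compound 2 to compound 4 (0.39 log units; beyond the scatter) and thus separates from the lower pair, with a 4.8-fold higher number from compound 3 to compound 4 (0.68 log units; beyond the scatter) against diethylamino. With a 1.2-fold lower number from compound 1 to compound 4 (0.08 log units; within the scatter) as the remaining step, the two groups bearing a further amine, 3-(dimethylamino)pyrrolidin-1-yl and 4-isopropylpiperazin-1-yl, now sit together on the higher side, and compounds 2 and 3 go with neither. No measurement at hand explains this split.

From the compounds shown here alone, whether the further amine alone goes with the higher numbers remains open. Plain pyrrolidin-1-yl and morpholin-4-yl would test this.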